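Fluoro-to-methoxy swap at two placements on the amide ring

The compounds below may be only part of what the source reports. "The series", "measured", "known", "first", "only" and "open" are said of these compounds alone.

Compound 1 `Cc1ccc(S(=O)(=O)NCc2ccc(CNC(=O)c3ccc(F)cc3)cc2)cc1` gives 1 nM in an assay on MDA-MB-231 cells for binding affinity to C-X-C chemokine receptor type 4 (Homo sapiens), read by immunofluorescence and microscopy, with stated times of 10 min and 30 min; on this read-out lower numbers stand for an effect already at smaller amounts and higher numbers for an effect only at larger amounts of compound. Compound 2 `COc1ccc(C(=O)NCc2ccc(CNS(=O)(=O)c3ccc(C)cc3)cc2)cc1` gives 100 nM in this assay, and compound 3 `Cc1ccc(S(=O)(=O)NCc2ccc(CNC(=O)c3ccccc3F)cc2)cc1` gives 1000 nM in this assay.

The change from compound 1 to compound 2 is methoxy in place of fluoro on an aromatic carbon, and it brought a 100-fold higher number from compound 1 to compound 2 (2.00 log units; beyond the scatter). The two cores differ as 2-fluorophenyl in place of 4-fluorophenyl on a carbonyl carbon, with a 1000-fold higher number from compound 1 to compound 3 (3.00 log units; beyond the scatter). Between compound 2 and compound 3 the record shows a 10-fold higher number from compound 2 to compound 3 (1.00 log units; beyond the scatter).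

Compound 4 `COc1ccccc1C(=O)NCc1ccc(CNS(=O)(=O)c2ccc(C)cc2)cc1` is not yet measured. Its difference from compound 3 is methoxy in place of fluoro on an aromatic carbon. Going by the values given here, this is the same kind of change as the one from compound 1 to compound 2, not the same: in compound 1 the group sits para to a large group, in compound 3 it sits ortho to a large group. Among the compounds with values here, the one measured instance of this kind of change, a 100-fold higher number from compound 1 to compound 2 (2.00 log units; beyond the scatter), moved the number upward by a wide margin. Whether that carries over to the other placement cannot be checked against any other pair here.

Within the data shown here, for compound 4 in this assay the expected step is a 10-fold higher number from compound 3 to compound 4 (1.00 log units; beyond the scatter), in the same direction as the earlier one but taken as smaller because the single precedent, a 100-fold higher number from compound 1 to compound 2 (2.00 log units; beyond the scatter), was measured at a different place. Compound 4 is accordingly estimated at 10000 nM, with a range from 1000 nM to 100000 nM.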

Compound 4, effective concentration (reported as EC, without a stated level of effect): 100 nM
Estimate against measurement, compound 4: 100-fold (2.00 log units) above; the whole stated range lies above it.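

In this assay, methoxy in place of fluoro on an aromatic carbon does not behave as a transferable step between the two placements: the same change on two cores in this assay, a 100-fold higher number (2.00 log units; beyond the scatter) from compound 1 to compound 2 and a 10-fold lower number (1.00 log units; beyond the scatter) from compound 3 to compound 4, 1000-fold (3.00 log units) apart, beyond the scatter of two such steps. With the group ortho to a large group the swap gives a 10-fold lower number from compound 3 to compound 4 (1.00 log units; beyond the scatter), and the two methoxy compounds show no change at the digits printed from compound 2 to compound 4 (within the scatter), so the 2-methoxyphenyl and 4-methoxyphenyl compounds cannot be told apart here, while a 100-fold higher number from compound 1 to compound 4 (2.00 log units; beyond the scatter) leaves compound 1, with its 4-fluorophenyl group, lowest of the four. This shows that, within these four compounds, the step measured on one core cannot be used to predict either the size or the direction of the step on the other; it rests on one pair per placement, however, and it does not establish a general rule for the series or give a reason for the reversal.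

Still open, as far as these compounds go, is whether a chloro, hydroxyl or amine group on this ring, or a longer chain such as ethoxy in place of methoxy, would follow the fluoro compounds, with their wide gap between placements, or the methoxy compounds, with none. Also open, from the compounds shown here alone, is whether the reversal persists when the 4-methylphenyl group on the sulfonyl end, shared by all four compounds, is replaced by another group, such as a carboxylic acid-bearing phenyl.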